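The compounds below may be only part of what the source reports. "The series", "measured", "known", "first", "only" and "open" are said of these compounds alone.

Measured so far:
compound 1, `CC(C)(C)NC(=O)c1cc(-c2ccc(Cl)cc2Cl)n[nH]1`, 398 nM
compound 2, `CN(C)C(=O)c1cc(-c2cc(F)c(Cl)cc2Cl)n[nH]1`, 324 nM

Both values come from an assay on isolated protein for inhibition of alkaline phosphatase, tissue-nonspecific isozyme (Homo sapiens); a higher number here means a weaker inhibitor, a lower number a stronger inhibitor. Compound 1 gives the highest of the two numbers, but its gap to compound 2 is within the scatter of the measurement, so the two compounds cannot be told apart on these figures. Compound 3, `O=C(c1cc(-c2ccc(Cl)cc2Cl)n[nH]1)N(CCO)CCO`, has not yet been measured in this assay. It shares its core with compound 1 and differs from it in one place: bis(2-hydroxyethyl)amino in place of (tert-butyl)amino on a carbonyl carbon. Among the measured compounds shown here, no step between two measured compounds that differ in only one place is known here, so the size of this change has to be guessed. Compound 1 at 398 nM and compound 2 at 324 nM carry different groups on the carbonyl carbon and yet give numbers within the scatter, which gives some hope that this position bears variation. For compound 3 a modest weakening is expected, a step of a 1.6-fold higher number from compound 1 to compound 3 (0.20 log units; within the scatter) that may still lie within the scatter. Compound 3 is therefore estimated at 630 nM, with a range from 200 nM to 2000 nM.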

Compound 3, half-maximal inhibitory concentration: 47 nM
The estimate for compound 3 lay 13-fold (1.13 log units) above the measured number; measured number below the stated range.
By their numbers in this assay, from the lowest: compound 3; then compounds 2 and 1 (each within the scatter of the next).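

In this assay, the group on the carbonyl carbon clearly matters on this core: bis(2-hydroxyethyl)amino in place of (tert-butyl)amino gives an 8.5-fold lower number from compound 1 to compound 3 (0.93 log units; beyond the scatter). This position therefore does more than tolerate variation, since one change here yields a stronger inhibitor, by a margin beyond the usual scatter. Nothing available explains this gain.

The compounds shown leave open which part of the entering group counts: its two oxygens, its two chains, or the absence of the amide hydrogen that (tert-butyl)amino carries. A diethylamino group, with the chains but no oxygens, and a single 2-hydroxyethylamino group, with one chain and the amide hydrogen, would help separate these features.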